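A few compounds are considered here, and "the series" means these few. Any claim that something is new, unique, unknown or untested is made for them only; others in the source may bear on it.

Measured so far:
Compound 1 `CN(C(=O)c1cc(-c2ccccc2Cl)on1)[C@H]1CN(S(=O)(=O)c2ccccc2)C[C@@H]1C(=O)N[C@H]1CCCNC1`: 0.06 10^-6 cm/s
Compound 2 `CN(C(=O)[C@H]1CN(S(=O)(=O)c2ccccc2)C[C@@H]1NC(=O)c1cc(-c2ccccc2Cl)on1)[C@H]1CCCNC1`: 0.11 10^-6 cm/s

These two results come from an ADME assay on Caco-2 cells (Homo sapiens) for permeability, in the apical to basolateral direction, at pH 7.4; a higher number here means that the compound crosses the layer faster, a lower number that the compound crosses the layer more slowly. In this assay, compound 2 gives 0.11 10^-6 cm/s, and this lies within the usual scatter of compound 1 at 0.06 10^-6 cm/s. Repeat measurements could account for the gap, so the two results are best read as one level rather than as a ranking.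

The next compound to test is compound 3 `CN(C(=O)[C@H]1CN(S(=O)(=O)c2ccccc2)C[C@@H]1N(C)C(=O)c1cc(-c2ccccc2Cl)on1)[C@H]1CCCNC1`. It is built from compound 2 by a single edit: methyl in place of hydrogen on an amide-type nitrogen, in words methyl in place of hydrogen on an amide-type nitrogen.

Among the measured compounds shown here, no measured pair here shows what this edit does, so the expectation starts from the level of compound 2 at 0.11 10^-6 cm/s and carries real uncertainty. A small upward move in this assay is the best guess, and it may well stay within the scatter. The estimated change is a 1.5-fold higher number from compound 2 to compound 3 (0.19 log units; within the scatter). For compound 3 the expected value is 0.17 10^-6 cm/s, with an estimated range of 0.06 10^-6 cm/s to 0.45 10^-6 cm/s.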

Compound 3, apparent permeability: 0.075 10^-6 cm/s
For compound 3 the middle estimate is 2.3-fold (0.36 log units) above the measured one; the measured number falls inside the stated range.
By their numbers in this assay, from the lowest: compounds 1, 3 and 2 (each within the scatter of the next).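

In this assay the swap of the amide hydrogen for methyl can now be read at two different amide-type nitrogens of the same molecule, since compound 3 carries a methyl on the nitrogen that holds a hydrogen in compound 2 and also on the one that holds a hydrogen in compound 1. The edit gives a 1.5-fold lower number from compound 2 to compound 3 (0.17 log units; within the scatter) at the first of these nitrogens and a 1.3-fold higher number from compound 1 to compound 3 (0.10 log units; within the scatter) at the second, so at neither place does the methyl move the number beyond what repeat measurements could produce, and compound 1, compound 2 and compound 3 read as a single low level. Nothing among the results offers an independent measurement that would explain this level.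

These steps cover only methyl and hydrogen on these nitrogens, so an ethyl group or a longer chain in the same place remains an open question. The basic question of what would lift the whole series clear of this level also stays open, since every compound shown keeps the same shared core and the same groups apart from these methyls.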